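This account rests on a few compounds, and the source may have more. Where it says the series, first, only, none or still open, it means among the compounds named here.

Two measured members of the series are compound 1, `Cc1nn(-c2ccccc2)c(Oc2ccc(Cl)cc2)c1/C=N/OCc1ccc(C(=O)OC(C)(C)C)cc1`, and compound 2, `CCOC(=O)c1ccc(CO/N=C/c2c(C)nn(C)c2Oc2ccc(Cl)cc2)cc1`. In a functional assay on HepG2 cells (Homo sapiens) for antiproliferative activity, tested at 1 uM (a higher number here means more inhibition at the concentration tested (going by the name of the read-out), a lower number less inhibition), compound 1 gives -31.1%, and compound 2 gives 27.4%, the higher of the two numbers, beyond the scatter. Among the measured compounds shown here, no single-change step between measured compounds is available. Compound 3, `CCOC(=O)c1ccc(CO/N=C/c2c(C)nn(-c3ccccc3)c2Oc2ccc(Cl)cc2)cc1`, differs from compound 2 by phenyl in place of methyl on an aromatic nitrogen. Compound 1 carries the same phenyl and sits low, but also differs in its ester, so this is only a partial lead. The step of a number 25.4 percentage points lower from compound 2 to compound 3 (beyond the scatter) is expected to be downward, beyond the scatter. Compound 3 is estimated at 2%, in the range -30% to 32%.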

Compound 3, a percentage reported as inhibition, at one concentration (the size of the read-out at that concentration, not a potency): -31.8%
Compound 3: middle estimate off by 33.8 percentage points, on the high side; measured number below the stated range.
By their numbers in this assay, from the lowest: compounds 3 and 1 (each within the scatter of the next); then compound 2.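

In this assay, phenyl in place of methyl on an aromatic nitrogen gives a number 59.2 percentage points lower from compound 2 to compound 3 (beyond the scatter) as a single-place change, so this position now has a direct reading. With phenyl held on that nitrogen, ethyl in place of tert-butyl on an oxygen next to a carbonyl group gives a number 0.7 percentage points lower from compound 1 to compound 3 (within the scatter) and does not separate the two esters. Nothing measured here accounts for the step at the nitrogen.

As far as these compounds go, whether an ethyl or benzyl group on that nitrogen keeps the number of compound 2 remains open. So does the effect of a carboxylic acid in place of the ester when methyl sits on the nitrogen.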